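Swapping an indanylamine arm onto the piperidine of compound 2

The compounds below may be only part of what the source reports. "The series", "measured", "known", "first", "only" and "open" are said of these compounds alone.

Compound 2 `CC(C)=CCN(C)C1CCN(CCCc2c[nH]c3ccc(-n4cnnc4)cc23)CC1` holds the lowest of the two numbers measured in an assay on CHO cells for displacement of a labelled ligand from 5-hydroxytryptamine receptor 1D (Homo sapiens) (on this read-out higher numbers stand for weaker inhibition and lower numbers for stronger inhibition), giving 0.5 nM. Compound 1 `C[C@@H](NCC1CCN(CCCc2c[nH]c3ccc(-n4cnnc4)cc23)CC1)c1ccccc1`, which carries a ((1-phenylethyl)amino)methyl arm instead, gives 1.4 nM. Compound 3 `c1ccc2c(c1)CCC2NCC1CCN(CCCc2c[nH]c3ccc(-n4cnnc4)cc23)CC1` is an unmeasured relative of compound 2 that differs in one place: ((2,3-dihydro-1H-inden-1-yl)amino)methyl in place of methyl(3-methylbut-2-en-1-yl)amino on a saturated ring carbon. Among the measured compounds shown here, the only step that bears on this change is a 2.8-fold lower number from compound 1 to compound 2 (0.45 log units; beyond the scatter), and compound 3 restores an aminomethyl arm bearing an aromatic group much as in compound 1. The number for compound 3 is therefore expected to rise by about a 3.0-fold higher number from compound 2 to compound 3 (0.48 log units; beyond the scatter), landing near that of compound 1. Compound 3 is estimated at 1.5 nM, within a range of 0.5 nM to 4.5 nM.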

Compound 3, half-maximal inhibitory concentration: 1.1 nM
Compound 3: the middle estimate sits 1.4-fold (0.13 log units) above what was measured; measured number inside the range.
By their numbers in this assay, from the lowest: compound 2; then compounds 3 and 1 (each within the scatter of the next).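

In this assay, ((2,3-dihydro-1H-inden-1-yl)amino)methyl in place of methyl(3-methylbut-2-en-1-yl)amino gives a 2.2-fold higher number from compound 2 to compound 3 (0.34 log units; beyond the scatter), so a second aromatic aminomethyl arm also stays behind compound 2. On the amine nitrogen, 2,3-dihydro-1H-inden-1-yl in place of 1-phenylethyl gives a 1.3-fold lower number from compound 1 to compound 3 (0.10 log units; within the scatter), so these two arms cannot be told apart. No supporting data explain either step.

Going by these compounds, the arm of compound 2 differs from the others in several features at once, so the feature behind its lower number stays open. On these data alone, how a benzyl or cyclohexyl group on the amine nitrogen would compare also remains unknown.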